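Cytotoxicity at the amide-ring nitrogen aryl group

This account rests on a few compounds, and the source may have more. Where it says the series, first, only, none or still open, it means among the compounds named here.

Measured so far in a functional assay on HEK293 cells (Homo sapiens) for cytotoxicity; a lower number here means that less compound is tolerated, a higher number that more compound is tolerated:
compound 1 `COc1ccc([C@H]2CC(=O)N(c3ccc(C)c(N)c3)C2)cc1OC1CCCC1`: > 10000 nM
compound 2 `COc1ccc([C@H]2CC(=O)N(c3cccc(C(F)(F)F)c3)C2)cc1OC1CCCC1`: > 10000 nM
compound 3 `COc1ccc([C@H]2CC(=O)N(c3ccc(S(C)(=O)=O)cc3)C2)cc1OC1CCCC1`: > 10000 nM

All three values are limits of this assay and not numbers. Compound 2 sits at such a limit, > 10000 nM, and nothing places it relative to the others. The step that the two limits leave unreadable from compound 1 to compound 2 and the step that the two limits leave unreadable from compound 2 to compound 3 are both unreadable because of the limit of > 10000 nM in this assay, at which 3 of the 3 values shown sit. The same holds for a step that the two limits leave unreadable from compound 1 to compound 3. No readable step in this assay exists anywhere in the set, so no size of effect for any change at the amide-type nitrogen in the ring is known.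

Compound 4 `COc1ccc([C@H]2CC(=O)N(c3cccc(NS(=O)(=O)c4ccccc4Br)c3)C2)cc1OC1CCCC1` differs from compound 2 by ((2-bromophenyl)sulfonyl)amino in place of trifluoromethyl on an aromatic carbon. For the measured compounds named here, no measured step bears on this change, and the only evidence is that every compound so far reached the limit. Compound 4 is therefore expected to behave like the others, estimated at 10000 nM with a range from 3000 nM to 30000 nM. The expected step is a number no higher from compound 2 to compound 4 (the limit leaves the size open), which is no step beyond the scatter; a measurement will decide.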

Compound 4, half-maximal cytotoxic concentration: > 10000 nM
Compound 4 ended at the assay's limit; the forecaster's own chance of this, stated with the estimate: 60%; the middle value sits exactly at the limit.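

In this assay compound 4 gives > 10000 nM, a limit and not a number. No step between compound 2 and compound 4 can be read, because both sit at a limit: the limit of > 10000 nM in this assay, at which 4 of the 4 values shown sit.

The compounds shown leave open what size of effect, if any, ((2-bromophenyl)sulfonyl)amino in place of trifluoromethyl has in this assay.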